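Ethynyl in place of 1-benzofuran-2-yl on the shared core

This account rests on a few compounds, and the source may have more. Where it says the series, first, only, none or still open, it means among the compounds named here.

Measured in a functional assay on HepG2 cells (Homo sapiens) for antiproliferative activity, read by XTT assay, with a stated time of 72 h; on this read-out lower numbers stand for stronger inhibition and higher numbers for weaker inhibition:
- compound 1 `COc1ncnc2c1c(-c1ccccc1)cn2[C@@H]1O[C@H](CO)[C@@H](O)[C@H]1O`: > 20000 nM
- compound 2 `COc1ncnc2c1c(-c1cc3ccccc3o1)cn2[C@@H]1O[C@H](CO)[C@@H](O)[C@H]1O`: > 20000 nM

Both entries are limits of the assay and not numbers. On these data alone, compound 2 gives only its limit of > 20000 nM, so its true position is unknown. The measured pair as a whole rests on (the limit of > 20000 nM in this assay, at which 2 of the 2 values shown sit).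

Compound 3 `C#Cc1cn([C@@H]2O[C@H](CO)[C@@H](O)[C@H]2O)c2ncnc(OC)c12` carries ethynyl in place of 1-benzofuran-2-yl on an aromatic carbon. For the measured compounds named here, the group that enters is far smaller by the count, and no measured compound carries it.

Going by the values given here, the one measured step that bears on this change is a step that the two limits leave unreadable from compound 1 to compound 2. It offers no size to carry over, and neither aromatic group produced a number. Any readable change from the limit of compound 2 can only run towards stronger inhibition, and another reading at the limit remains quite possible. The expected move is modest and uncertain: an at least 2.0-fold lower number from compound 2 to compound 3 (0.30 log units; that floor lies within the scatter). In this assay compound 3 is estimated at 10000 nM, with an expected range from 1000 nM to 20000 nM.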

Compound 3, half-maximal inhibitory concentration: 12700 nM
Compound 3: the middle estimate sits 1.3-fold (0.10 log units) below what was measured; measured number inside the range.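

In this assay, for the compounds shown here, compound 3 gives 12700 nM, the first actual number for any group at this place on the shared core, two ring bonds from the ring nitrogen. On these data alone, exchanging the aromatic groups for ethynyl gives an at least 1.5-fold lower number from compound 2 to compound 3 (0.19 log units; that floor lies within the scatter) and an at least 1.5-fold lower number from compound 1 to compound 3 (0.19 log units; that floor lies within the scatter); both sizes are only floors, and the true gaps remain unknown, while the step between the two aromatic compounds cannot be read. The result therefore shows that antiproliferative activity becomes measurable in this assay with ethynyl at this aromatic carbon, whereas phenyl and 1-benzofuran-2-yl gave no number, and the series as a whole still leans on one assay limit: the limit of > 20000 nM in this assay, at which 2 of the 3 values shown sit.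

The compounds shown do not settle whether the readable value depends on the triple bond or simply on the absence of a ring at this place, and a comparison with a nitrile or a small alkyl group such as ethyl would separate those two readings. As far as these compounds go, whether an amine, a carboxylic acid or a longer chain ending in a hydroxyl group at the same carbon would give a lower number than compound 3 also remains open.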